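Chloro to hydroxy in a series at the limit

The source may report more compounds than this note shows. Statements on the series, on what has been measured and on what is new or still open speak of the compounds shown alone.

- compound 1 `COc1cccc(/C=C/C(=O)c2ccc(OC)c3c2OC(C)(C)C=C3)c1` gives > 10000 nM as a limit
- compound 2 `COc1ccc(/C=C/C(=O)c2ccc(OC)c3c2OC(C)(C)C=C3)cn1` gives > 10000 nM as a limit
- compound 3 `COc1ccc(C(=O)/C=C/c2ccc(Cl)cc2)c2c1C=CC(C)(C)O2` gives > 10000 nM as a limit

All three compounds were tested in a functional assay on SW-620 cells (Homo sapiens) for antiproliferative activity, read by MTT assay, with a stated time of 24 h (a higher number here means a weaker inhibitor, a lower number a stronger inhibitor), and none gave a number. For the measured compounds named here, the series so far stands at the limit of > 10000 nM in this assay, at which 3 of the 3 values shown sit, and compound 3 shares that position, so its true potency is unknown and no order can be drawn among the three.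

The next compound is compound 4 `COc1ccc(C(=O)/C=C/c2ccc(O)cc2)c2c1C=CC(C)(C)O2` with hydroxy in place of chloro on an aromatic carbon para to a large group, which counts as hydroxy in place of chloro on an aromatic carbon and turns 4-chlorophenyl into 4-hydroxyphenyl.

Going by the values given here, three measured steps bear on this change, since each exchanges the whole group that carries the chloro in compound 3: a step that the two limits leave unreadable from compound 1 to compound 2 and a step that the two limits leave unreadable from compound 1 to compound 3 and a step that the two limits leave unreadable from compound 2 to compound 3 all remain without a readable size. They give no measured effect of any exchange at this group and no direction for the new one.

The expected outcome is no readable change, so the estimated step that the limit leaves unreadable from compound 3 to compound 4 has no direction that the data can support. Compound 4 is expected to stay weak and may well report only a limit. Compound 4 is estimated at 20000 nM with an expected range from 6000 nM to 60000 nM in this assay as the working figure.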

Compound 4, half-maximal inhibitory concentration: > 10000 nM
Compound 4: only a limit was reported (the forecaster's own chance of this, stated with the estimate: 70%); the middle value is on the limit's open side.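

In this assay compound 4 gives > 10000 nM, which is a limit and not a number. For the compounds shown here, no step linking compound 4 to compound 1, compound 2 or compound 3 can be read. The series holds a single position: the limit of > 10000 nM in this assay, at which 4 of the 4 values shown sit.

The compounds shown leave open how the four rank in true potency and whether any exchange at this group alters it.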